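Switching the aryl group on the shared core: compound 4

The compounds below may be only part of what the source reports. "The series", "measured", "known", "first", "only" and "open" are said of these compounds alone.

The measured compounds:
Compound 1, `COc1cccc(-c2cn(C)c(=O)c3[nH]c(C(=O)NCc4ccc(C(=O)Nc5ccccc5N)cc4)cc23)c1`, gives 250 nM.
Compound 2, `Cn1cc(-c2ccccc2Oc2ccccc2)c2cc(C(=O)NCCCC(=O)NO)[nH]c2c1=O`, gives 380 nM.
Compound 3, `Cn1cc(-c2ccccc2Oc2ccccc2)c2cc(C(=O)NCCCCCC(=O)Nc3ccccc3N)[nH]c2c1=O`, gives 70 nM.

All three numbers come from a functional assay on MV4-11 cells (Homo sapiens) for antiproliferative activity, read by CCK-8 assay, with a stated time of 72 h; on this read-out lower numbers stand for stronger inhibition and higher numbers for weaker inhibition. Compound 1 stands second highest of the three; compound 2 lies within the scatter of it, while compound 3 sits lower by an amount beyond the scatter. Among the measured compounds shown here, the one single-point step measured so far, a 5.4-fold lower number from compound 2 to compound 3 (0.73 log units; beyond the scatter), concerns the chain end, where 2-((2-aminophenyl)carbamoyl)ethyl replaced hydroxycarbamoyl; it tells nothing about the aryl group.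

Compound 4, `Cc1ccccc1-c1cn(C)c(=O)c2[nH]c(C(=O)NCc3ccc(C(=O)Nc4ccccc4N)cc3)cc12`, differs from compound 1 as follows: 2-methylphenyl in place of 3-methoxyphenyl on an aromatic carbon. For the measured compounds named here, no measured pair shares this change, so the expectation rests only on the value of compound 1 in this assay, which is 250 nM. Compound 4 is therefore expected to move by no more than the scatter, and the estimated step is no change at the digits printed from compound 1 to compound 4 (within the scatter). Compound 4 is estimated at 250 nM, with a range from 90 nM to 700 nM.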

Compound 4, half-maximal inhibitory concentration: 310 nM
Beside the measured number, compound 4's estimate is 1.2-fold (0.09 log units) below it; low and high end bracket the measured number.
By their numbers in this assay, from the lowest: compound 3; then compounds 1, 4 and 2 (each within the scatter of the next).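

In this assay, among the compounds shown here, the aryl group on the shared core can now be read directly for the first time, and 2-methylphenyl in place of 3-methoxyphenyl gives a 1.2-fold higher number from compound 1 to compound 4 (0.09 log units; within the scatter) on the same chain end. The entering group carries no hydrogen-bond acceptor and the leaving group carries one, yet this pair shows no difference beyond the scatter, so on this core and chain end the acceptor is not shown to matter in this read-out. No evidence on the cause of this result is at hand.

On these data alone, it remains open whether the 2-phenoxyphenyl group of compound 2 and compound 3 would read differently on the chain end of compound 1. As far as these compounds go, how an aryl group bearing an amine or a carboxylic acid, or a pyridine ring, would read at this place also remains open.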